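Bromo for methyl on the sulfonyl-bearing ring

The source may hold more compounds than are shown below. What is called first, only, known or untested is meant among the compounds shown, and "the series" means these compounds.

Measured so far in a functional assay on A549 cells (Homo sapiens) for cytotoxicity, read by MTT assay, with a stated time of 72 h; a higher number here means a weaker inhibitor, a lower number a stronger inhibitor:
- compound 1, `Cc1ccc(S(=O)(=O)c2nc3ccccc3nc2Nc2ccccc2)cc1`: 12500 nM
- compound 3, `Cc1ccc(S(=O)(=O)c2nc3ccccc3nc2Nc2ccc(C(F)(F)F)cc2)cc1`: 13500 nM
- compound 2, `COc1ccc(Nc2nc3ccccc3nc2S(=O)(=O)c2ccc(C)cc2)cc1`: only a limit, > 50000 nM

Compound 1 gives the lower of the two numbers shown, with compound 3 close by; the two lie within the scatter of each other, so no order between them is claimed. The limit for compound 2 is the limit of > 50000 nM in this assay, at which 1 of the 3 values shown sits.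

The measured steps all sit on the aniline-side ring: an at least 4.0-fold higher number from compound 1 to compound 2 (0.60 log units; beyond the scatter); a 1.1-fold higher number from compound 1 to compound 3 (0.03 log units; within the scatter); an at least 3.7-fold lower number from compound 2 to compound 3 (0.56 log units; beyond the scatter). None touches the ring that carries the sulfonyl group.

Compound 4, `O=S(=O)(c1ccc(Br)cc1)c1nc2ccccc2nc1Nc1ccccc1`, differs from compound 1 there: bromo in place of methyl on an aromatic carbon. Going by the values given here, no measured step bears on this ring, so the expectation rests on compound 1 alone, with the change taken as neutral. The expected step is no change at the digits printed from compound 1 to compound 4 (within the scatter), which is none beyond the scatter. For compound 4 the estimate in this assay is 12500 nM, expected between 4000 nM and 40000 nM.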

Compound 4, half-maximal inhibitory concentration: 10800 nM
For compound 4 the middle estimate is 1.2-fold (0.06 log units) above the measured one; the range from low to high includes it.
By their numbers in this assay, from the lowest: compounds 4, 1 and 3 (each within the scatter of the next). At a limit, above all of these: compound 2.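

On the ring that carries the sulfonyl group, the change from 4-methylphenyl to 4-bromophenyl gives a 1.2-fold lower number from compound 1 to compound 4 (0.06 log units; within the scatter) in this assay, the only step shown at this position. The place on a six-membered aromatic ring of carbon only, para to a large group, therefore accepts bromo in place of methyl with no change that can be read in this assay, so the two groups are not told apart here. Nothing at hand gives a cause for this step or bears on it.

As far as these compounds go, how this position responds to a group of a different kind, such as an amine, a carboxylic acid or a longer chain, remains open. Also open, from the compounds shown here alone, is whether bromo on this ring would read the same alongside the methoxy or trifluoromethyl groups on the aniline-side ring.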